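The source may hold more compounds than are shown below. What is called first, only, known or untested is meant among the compounds shown, and "the series" means these compounds.

In an ADME assay on HEK293 cells (Homo sapiens) for cytotoxicity, read by CellTiter-Glo and resazurin assay, with a stated time of 72 h (a higher number here means that more compound is needed for the effect, a lower number that less compound is needed), compound 3 `CC(C)N(Cc1cccc(OCCCCCC(=O)O)c1)C(=O)c1ccc(-c2ccc3[nH]ccc3c2)cc1` gives only a limit of the assay, > 26000 nM. Compound 1 `CC(C)N(Cc1cccc(OCCCCCC(=O)O)c1)C(=O)c1ccc(-c2cccc3ccccc23)cc1` likewise reaches only a limit in this assay, > 26000 nM. Compound 2 `CC(=O)Nc1cccc(-c2ccc(C(=O)N(Cc3cccc(OCCCCCC(=O)O)c3)C(C)C)cc2)c1` also gives only a limit there, > 26000 nM. All three measured compounds thus share the same limit, (the limit of > 26000 nM in this assay, at which 3 of the 3 values shown sit), so compound 3 cannot be ranked against either of the others. The change to compound 4 `CC(C)N(Cc1cccc(OCCCCCC(=O)O)c1)C(=O)c1ccc(-c2cccc(C(F)(F)F)c2)cc1` is 3-(trifluoromethyl)phenyl in place of 1H-indol-5-yl on an aromatic carbon. For the measured compounds named here, no measured step exchanges these same two groups; the nearest comparisons are a step that the two limits leave unreadable from compound 1 to compound 3, a step that the two limits leave unreadable from compound 1 to compound 2 and a step that the two limits leave unreadable from compound 2 to compound 3, each of which the two limits leave without a readable size, so none of them shows whether exchanging the ring at this carbon moves the value at all. Because the limit of > 26000 nM in this assay, at which 3 of the 3 values shown sit, holds for every value shown, compound 4 is expected to come out again at or near that limit, an estimated step that the limit leaves unreadable from compound 3 to compound 4. Compound 4 is therefore estimated at 30000 nM, within a range of 15000 nM to 60000 nM.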

Compound 4, half-maximal effective concentration: > 26000 nM
Compound 4: only a limit was reported (the forecaster's own chance of this, stated with the estimate: 80%); the middle value does not contradict the limit.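

In this assay compound 4 gives > 26000 nM, which is only a limit. Its steps from compound 1, compound 2 and compound 3 therefore cannot be read. The compounds shown leave open whether any exchange at this aromatic carbon moves the value at all, because all of them rest on one limit: the limit of > 26000 nM in this assay, at which 4 of the 4 values shown sit.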